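Adding one chloro to the benzyl group of compound 3

The source may hold more compounds than are shown below. What is called first, only, known or untested is meant among the compounds shown, and "the series" means these compounds.

Measured in a functional assay on A549 cells (Homo sapiens) for cytotoxicity, read by MTT assay, with a stated time of 72 h; on this read-out higher numbers stand for weaker inhibition and lower numbers for stronger inhibition:
- compound 1 `CCN(CC)Cc1ccc2nc(NC(=O)N/N=C/c3cn(Cc4ccc(Cl)cc4Cl)c4ccccc34)sc2c1`: 1900 nM
- compound 2 `CC1CCN(Cc2ccc3nc(NC(=O)N/N=C/c4cn(Cc5ccccc5Cl)c5ccccc45)sc3c2)CC1`: 3330 nM
- compound 3 `CCN(CC)Cc1ccc2nc(NC(=O)N/N=C/c3cn(Cc4ccccc4)c4ccccc34)sc2c1`: 3330 nM

Compound 3 stands level with compound 2, and neither number sits beyond the scatter from that of compound 1. Compound 4 `CCN(CC)Cc1ccc2nc(NC(=O)N/N=C/c3cn(Cc4ccccc4Cl)c4ccccc34)sc2c1` has chloro in place of hydrogen on an aromatic carbon, turning benzyl into 2-chlorobenzyl: chloro in place of hydrogen on an aromatic carbon. Within the data shown here, the one measured step at this group, phenyl in place of 2,4-dichlorophenyl, is a 1.8-fold higher number from compound 1 to compound 3 (0.24 log units; within the scatter). Even with two chloro groups involved, that step stays small. Compound 2 also carries 2-chlorobenzyl, on a different amine, and gives 3330 nM. One chloro is therefore expected to cause no change beyond the scatter in this assay. The estimated step is a 1.2-fold lower number from compound 3 to compound 4 (0.09 log units; within the scatter). For compound 4 the expected value is 2700 nM, with an estimated range of 1400 nM to 5000 nM.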

Compound 4, half-maximal inhibitory concentration: 1390 nM
For compound 4 the middle estimate is 1.9-fold (0.29 log units) above the measured one, and the stated range ends above it.
By their numbers in this assay, from the lowest: compounds 4, 1, 2 and 3 (each within the scatter of the next, the first and the last beyond it).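

In this assay, among these compounds, a single chloro on the benzyl group gives a 2.4-fold lower number from compound 3 to compound 4 (0.38 log units; beyond the scatter) and is the first step at this group to pass beyond the scatter. With 2-chlorobenzyl held constant, diethylamino in place of 4-methylpiperidin-1-yl gives a 2.4-fold lower number from compound 2 to compound 4 (0.38 log units; beyond the scatter) as well, so the amine also counts. Taking away the second chloro gives a 1.4-fold lower number from compound 1 to compound 4 (0.14 log units; within the scatter) and stays within the scatter, so one chloro on the benzyl group does as well as two here.

On these data alone, whether bromo or methoxy in place of this chloro would act alike stays open, as does morpholine in place of the amine. No measured evidence accounts for these steps.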